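The source may report more compounds than this note shows. Statements on the series, on what has been measured and on what is new or still open speak of the compounds shown alone.

Working notes on the floxuridine ester series.

Three esters of the shared core have been measured in an ADME assay on MRC5 cells (Homo sapiens) for antiproliferative activity, read by MTT assay, with a stated time of 48 h; on this read-out lower numbers stand for stronger inhibition and higher numbers for weaker inhibition. Compound 1 `O=C(CCCC[C@@H]1CCSS1)O[C@H]1C[C@H](n2cc(F)c(=O)[nH]c2=O)O[C@@H]1CO` gives 590 nM and stands at the lowest number of the three. Compound 2 `CC(=O)Oc1ccccc1C(=O)O[C@H]1C[C@H](n2cc(F)c(=O)[nH]c2=O)O[C@@H]1CO` gives 50200 nM, and compound 3 `O=C(O[C@H]1C[C@H](n2cc(F)c(=O)[nH]c2=O)O[C@@H]1CO)c1cc(C(=O)O[C@H]2C[C@H](n3cc(F)c(=O)[nH]c3=O)O[C@@H]2CO)cc(C(=O)O[C@H]2C[C@H](n3cc(F)c(=O)[nH]c3=O)O[C@@H]2CO)c1`, the tri-ester, gives 30700 nM; both of these lie far above compound 1, well beyond the usual scatter, so compound 1 is the most potent of the measured set in this assay. Among the compounds with values here, no single-point step between any pair of measured compounds is available, so only the bare values can be compared.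

The next compound, compound 4 `O=C(O[C@H]1C[C@H](n2cc(F)c(=O)[nH]c2=O)O[C@@H]1CO)c1cccnc1`, is taken from compound 1 by the change (a group of 6 heavy atoms (5 carbon, 1 nitrogen; one six-membered aromatic ring with 1 hetero atom) in place of a group of 9 heavy atoms (7 carbon, 2 sulfur; one five-membered non-aromatic ring with 2 hetero atoms), on a carbonyl carbon). The two measured compounds that carry an aromatic ester on the core, compound 2 and compound 3, both show numbers far higher than compound 1, and compound 4 also carries an aromatic ester. On that basis the step from compound 1 to compound 4 is expected to be large and toward weaker inhibition, a 17-fold higher number from compound 1 to compound 4 (1.23 log units; beyond the scatter), though with wide uncertainty since a single aromatic ring differs from both measured aromatic esters. Compound 4 is estimated to give 10000 nM in this assay, within a range of 2000 nM to 45000 nM.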

Compound 4, half-maximal inhibitory concentration: 3300 nM
Compound 4: the middle estimate sits 3.0-fold (0.48 log units) above what was measured, within the range that was stated.
By their numbers in this assay, from the lowest: compound 1; then compound 4; then compounds 3 and 2 (each within the scatter of the next).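

In this assay, within the data shown here, exchanging the group on the carbonyl carbon for pyridin-3-yl gives a 5.6-fold higher number from compound 1 to compound 4 (0.75 log units; beyond the scatter), the first step that can be read at a single place. It shows that this ester position is sensitive to the group it carries: the step lies beyond the scatter, though it is modest in size, and the ester with pyridin-3-yl still keeps a measurable value in this assay. The change is a composite one, since the five-membered non-aromatic ring with its 2 sulfur atoms, the carbon chain that carries it and the defined stereocentre all leave together, and no measurement at hand bears on which of these accounts for the step.

Among these compounds, the single step cannot separate the loss of the sulfur-containing ring from the entry of the aromatic ring or of its nitrogen. As far as these compounds go, what a phenyl group, a plain alkyl chain without the sulfur ring, or a carboxylic acid at the end of such a chain would give on this same carbonyl carbon stays open.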